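Methylating the Ring Nitrogen of Compound 1

The source may hold more compounds than are shown below. What is called first, only, known or untested is meant among the compounds shown, and "the series" means these compounds.

Compound 1 `CN1CCN(c2nc(-c3cccc(Cl)c3)nc3[nH]cnc23)CC1`: 29.9%
Compound 2 `CN1CCN(c2nc(-c3cc(Cl)ccc3Cl)nc3[nH]cnc23)CC1`: 13%

Among the compounds with values here, in an assay on cells for displacement of a labelled ligand from adenosine receptor A2b (Homo sapiens), read by scintillation counting and radioligand binding, with a stated time of 30 min, tested at 10 uM (on this read-out lower numbers stand for less inhibition and higher numbers for more inhibition at the one concentration tested (going by the name of the read-out)), compound 1 gives 29.9%, the higher of the two measured numbers, while compound 2 gives 13%; the single measured step is a number 16.9 percentage points lower from compound 1 to compound 2 (beyond the scatter).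

Compound 3 `CN1CCN(c2nc(-c3cccc(Cl)c3)nc3c2ncn3C)CC1` differs from compound 1 by methyl in place of hydrogen on an aromatic nitrogen. Within the data shown here, the one measured step concerns a chloro on an aromatic carbon and does not bear on a change at the ring nitrogen, so no guidance on size or direction is available. Compound 3 is therefore expected to move by a number 4.9 percentage points lower from compound 1 to compound 3 (within the scatter), a step not beyond the scatter. Compound 3 is estimated at 25%, with a range from 5% to 45%.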

Compound 3, a percentage reported as inhibition, at one concentration (the size of the read-out at that concentration, not a potency): 19.2%
The estimate for compound 3 lay 5.8 percentage points above the measured number, within the range that was stated.
By their numbers in this assay, from the lowest: compounds 2 and 3 (each within the scatter of the next); then compound 1.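

Methyl in place of hydrogen on an aromatic nitrogen of the five-membered aromatic ring gives a number 10.7 percentage points lower from compound 1 to compound 3 (beyond the scatter). Within the data shown here, this shows that the ring nitrogen, which the earlier compounds left unchanged, is a place where even one added carbon moves the number, and here it moves it down. Nothing measured here accounts for this step. As far as these compounds go, whether ethyl, a longer chain or a chain carrying an amine on this nitrogen would give a different number remains open. So does whether methyl would have a similar effect on compound 2.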